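Diazine replacements on the aryl sulfonamide core

The compounds below may be only part of what the source reports. "The series", "measured", "known", "first", "only" and "open" are said of these compounds alone.

Measured so far:
compound 1 `CC(C)(C)c1ccc(S(=O)(=O)Nc2ccc(Cl)cc2-c2ncccc2CN)cc1` gives 3160 nM
compound 2 `CNc1ncc(O)c(-c2cc(Cl)ccc2NS(=O)(=O)c2ccc(C(C)(C)C)cc2)n1` gives 27 nM
compound 3 `CN(C)c1ncnc(-c2cc(Cl)ccc2NS(=O)(=O)c2ccc(C(C)(C)C)cc2)c1O` gives 9 nM

In a functional assay on isolated protein for antagonist activity at C-C chemokine receptor type 9 (Homo sapiens), read by calcium flux, with a stated time of 10 min (a higher number here means a weaker inhibitor, a lower number a stronger inhibitor), compound 1 stands at the highest number of the three, with compound 2 as its nearest neighbour and compound 3 furthest away. The two measured steps from compound 1 both run the same way: a 120-fold lower number from compound 1 to compound 2 (2.07 log units; beyond the scatter) and a 350-fold lower number from compound 1 to compound 3 (2.55 log units; beyond the scatter). Between the two diazines themselves the step is smaller, a 3.0-fold lower number from compound 2 to compound 3 (0.48 log units; beyond the scatter).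

Compound 4 `CC(C)(C)c1ccc(S(=O)(=O)Nc2ccc(Cl)cc2-c2nccnc2NCCO)cc1` is the next step from compound 1. The change is a group of 10 heavy atoms (6 carbon, 3 nitrogen, 1 oxygen; one six-membered aromatic ring with 2 hetero atoms) in place of a group of 8 heavy atoms (6 carbon, 2 nitrogen; one six-membered aromatic ring with 1 hetero atom), on an aromatic carbon. As in compound 2 and compound 3, a six-membered aromatic ring with one hetero atom gives way to one with two hetero atoms carrying a nitrogen and an oxygen, so the two large steps from compound 1 are the relevant precedent; the entering group differs from both in how the oxygen is carried, so a somewhat smaller step is expected. For compound 4 the expected step is a 32-fold lower number from compound 1 to compound 4 (1.50 log units; beyond the scatter), and the estimated value in this assay is 100 nM, with a range of 20 nM to 500 nM.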

Compound 4, half-maximal inhibitory concentration: 34 nM
The estimate for compound 4 lay 2.9-fold (0.47 log units) above the measured number, within the range that was stated.
By their numbers in this assay, from the lowest: compound 3; then compounds 2 and 4 (each within the scatter of the next); then compound 1.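

In this assay, the large gain over compound 1 at this position does not depend on the oxygen sitting directly on the new ring: with the oxygen carried on a chain, the change still gives a 93-fold lower number from compound 1 to compound 4 (1.97 log units; beyond the scatter). Compound 4 cannot be separated from the other diazine-type replacement, since a 1.3-fold higher number from compound 2 to compound 4 (0.10 log units; within the scatter) stays within the scatter, whereas a 3.8-fold higher number from compound 3 to compound 4 (0.58 log units; beyond the scatter) is a modest step that leaves compound 3 with the lowest number of the series. Nothing available here bears on why these replacements differ.

Going by these compounds, whether the hydroxyl of compound 4 contributes at all stays open, since these compounds include no version of that chain ending in a methyl group. On these data alone, what a longer chain or a carboxylic acid at that end would give also remains open.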